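Adding chlorine and a hydroxyl to the benzyl ring

The compounds below may be only part of what the source reports. "The series", "measured", "known", "first", "only" and "open" are said of these compounds alone.

Measured compounds:
compound 1 `CSc1ccc(CSc2nc(-c3ccc(F)cc3)c(-c3ccncc3)[nH]2)cc1` with 670 nM in a functional assay (Homo sapiens) for inhibition; a higher number here means a weaker inhibitor, a lower number a stronger inhibitor
compound 2 `CSc1ccc(CSc2nc(-c3ccc(Cl)cc3)c(-c3ccncc3)[nH]2)cc1` with 2200 nM

Compound 1 gives the lowest of the two numbers; its nearest neighbour is compound 2, reached by a 3.3-fold higher number from compound 1 to compound 2 (0.52 log units; beyond the scatter) after chloro in place of fluoro on an aromatic carbon. Compound 3 `CSc1cc(Cl)cc(CSc2nc(-c3ccc(F)cc3)c(-c3ccncc3)[nH]2)c1O` is not yet measured. It differs from compound 1 as follows: 5-chloro-2-hydroxy-3-(methylsulfanyl)phenyl in place of 4-(methylsulfanyl)phenyl on a saturated chain carbon bound to a sulfur. Among the measured compounds shown here, no measured step touches this part of the molecule; the one known step concerns a different ring, so it gives no direct guide. Compound 3 is therefore expected near compound 1, with a wide range: 1000 nM (200 nM to 5000 nM), a step of a 1.5-fold higher number from compound 1 to compound 3 (0.17 log units; within the scatter).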

Compound 3, half-maximal inhibitory concentration: 640 nM
The estimate for compound 3 lay 1.6-fold (0.19 log units) above the measured number; the range from low to high includes it.
By their numbers in this assay, from the lowest: compounds 3 and 1 (each within the scatter of the next); then compound 2.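

The step of a 1.0-fold lower number from compound 1 to compound 3 (0.02 log units; within the scatter) in this assay shows that this position, on a saturated chain carbon bound to a sulfur, accepts the larger 5-chloro-2-hydroxy-3-(methylsulfanyl)phenyl group with no loss of inhibition. Among the compounds shown here, the earlier compounds had changed only the other ring, so this is the first reading on the benzyl ring. No available evidence explains the result. The chlorine and the hydroxyl enter together, and the compounds shown do not separate what each contributes. From the compounds shown here alone, how an amine or a carboxylic acid on this ring would fare also remains open.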